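The source may hold more compounds than are shown below. What is called first, only, known or untested is meant among the compounds shown, and "the series" means these compounds.

Measured in a functional assay on U-87MG ATCC cells for antiproliferative activity against U-87 MG (Homo sapiens), read by spectrophotometry, with a stated time of 2 days; a lower number here means a stronger inhibitor of growth, a higher number a weaker inhibitor of growth:
- compound 1 `COc1ccc(Nc2ncc(C(F)(F)F)c(N3Cc4cccc(N(C)S(C)(=O)=O)c4C3)n2)cc1C(F)(F)F`: 29400 nM
- compound 2 `Cc1ccc(Nc2ncc(C(F)(F)F)c(N3Cc4cccc(N(C)S(C)(=O)=O)c4C3)n2)cc1C`: > 30000 nM (a limit of the assay, not a number)
- compound 3 `COc1cc(Nc2ncc(C(F)(F)F)c(N3Cc4cccc(N(C)S(C)(=O)=O)c4C3)n2)c(OC)cc1Cl`: 6200 nM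

For the measured compounds named here, compound 3 stands lowest so far, and it is the only compound whose number falls clearly away from the others. The two measured steps that bear on the next change are a 4.7-fold lower number from compound 1 to compound 3 (0.68 log units; beyond the scatter) and an at least 4.8-fold lower number from compound 2 to compound 3 (0.68 log units; beyond the scatter). Both lie beyond the scatter, and both arrive at the 4-chloro-2,5-dimethoxyphenyl group.

Compound 4 `Cc1cc(F)ccc1Nc1ncc(C(F)(F)F)c(N2Cc3cccc(N(C)S(C)(=O)=O)c3C2)n1` has not been measured in this assay. The change is 4-fluoro-2-methylphenyl in place of 4-chloro-2,5-dimethoxyphenyl on a nitrogen on an aromatic ring. Going by the values given here, this removes the one group tied to a lower number, so a move back upward is expected, of roughly the size of those two steps or somewhat smaller. The estimated step is a 2.6-fold higher number from compound 3 to compound 4 (0.41 log units; beyond the scatter). A limit result also remains possible, given (the limit of > 30000 nM in this assay, at which 1 of the 3 values shown sits). For compound 4 the expected value is 16000 nM, with an estimated range of 6000 nM to 32000 nM.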

Compound 4, concentration for 50% growth inhibition: > 30000 nM
Compound 4 was reported as a limit; the forecaster's own chance of this, stated with the estimate: 30%; middle value at least 1.8-fold (0.27 log units) from the limit.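

In this assay the change at this nitrogen gives an at least 4.8-fold higher number from compound 3 to compound 4 (0.68 log units; beyond the scatter), so a third aryl group in place of the 4-chloro-2,5-dimethoxyphenyl group also fails to keep the lower number. Against the other partner there is only an at least 1.0-fold higher number from compound 1 to compound 4 (0.00 log units; that floor lies within the scatter), which leaves compound 4 not separable from compound 1, and the step between compound 2 and compound 4 cannot be read. Compound 4 gives a limit of the assay, not a number, and the series now collects at that ceiling: the limit of > 30000 nM in this assay, at which 2 of the 4 values shown sit.

Which part of the 4-chloro-2,5-dimethoxyphenyl group carries the lower number stays open, since the chlorine and the two methoxy groups occur together only in compound 3. Also open, from the compounds shown here alone, is how this nitrogen's aryl ring would behave carrying a morpholine or a carboxylic acid.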